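A few compounds are considered here, and "the series" means these few. Any claim that something is new, unique, unknown or untested is made for them only; others in the source may bear on it.

Measured in an ADME assay on HCT-116 cells (Homo sapiens) for cytotoxicity, read by CellTiter-Glo, with a stated time of 72 h; a lower number here means a stronger inhibitor, a higher number a weaker inhibitor:

Compound 1 `Cc1cc(C)c(S(=O)(=O)N2CCC(N3CCC(C)CC3)CC2)c(C)c1`: > 5000 nM
Compound 2 `Cc1cc(C)c(S(=O)(=O)N2CCC(N3CCC(C(C)C)CC3)CC2)c(C)c1`: > 5000 nM
Compound 3 `Cc1cc(C)c(S(=O)(=O)N2CCC(N3CCC(O)CC3)CC2)c(C)c1`: > 5000 nM

Each of these entries is a limit of the test and not an exact number. Compound 3 therefore has no measured potency, only its limit of > 5000 nM.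

Compound 4 `Cc1cc(C)c(S(=O)(=O)N2CCC(C(=O)N3CCC(C)CC3)CC2)c(C)c1` differs from compound 3 in one place, with (4-methylpiperidin-1-yl)carbonyl in place of 4-hydroxypiperidin-1-yl on a saturated ring carbon.

Three measured steps offer a comparison: a step that the two limits leave unreadable from compound 1 to compound 2, a step that the two limits leave unreadable from compound 1 to compound 3 and a step that the two limits leave unreadable from compound 2 to compound 3. Each also exchanges one group on a saturated ring carbon, but none has a readable size, and none makes this same exchange. They give no direction for the new change. Within the data shown here, the only firm guide is the limit of > 5000 nM in this assay, at which 3 of the 3 values shown sit. In this assay, no step beyond the usual scatter is therefore expected, and compound 4 will probably also be reported only as a limit.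

If a number is obtained, compound 4 is expected to give about 6000 nM, with an estimated range from 3000 nM to 15000 nM.

This estimate means an expected step that the limit leaves unreadable from compound 3 to compound 4.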

Compound 4, half-maximal inhibitory concentration: > 5000 nM
Compound 4: a limit, no number (the forecaster's own chance of this, stated with the estimate: 85%); the middle value is on the limit's open side.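

In this assay compound 4 gives > 5000 nM, which is a limit and not a number. Its steps to compound 1, compound 2 and compound 3 therefore cannot be read. The compounds shown leave open whether any change to the shared core would give a measurable number, as every result is still a limit: the limit of > 5000 nM in this assay, at which 4 of the 4 values shown sit.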